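Swapping a chlorophenyl for a fluorophenyl group

The compounds below may be only part of what the source reports. "The series", "measured", "known", "first", "only" and "open" are said of these compounds alone.

Compound 1 `CC1(C)OC(C)(C)c2c1nnc(-c1cccc(C(F)(F)F)c1)[n+]2[O-]`: 66.7 mg/kg
Compound 2 `CC1(C)OC(C)(C)c2c1nnc(-c1cccc(Cl)c1)[n+]2[O-]`: 500 mg/kg

Among the measured compounds shown here, in a functional assay on the whole organism with Mus musculus as the target (on this read-out higher numbers stand for an effect only at larger amounts of compound and lower numbers for an effect already at smaller amounts), compound 2 shows the highest of the two numbers measured so far; the only measured step, a 7.5-fold higher number from compound 1 to compound 2 (0.87 log units; beyond the scatter), separates it from compound 1. Compound 3 `CC1(C)OC(C)(C)c2c1nnc(-c1ccc(F)cc1)[n+]2[O-]` differs from compound 2 by 4-fluorophenyl in place of 3-chlorophenyl on an aromatic carbon. For the measured compounds named here, no measured step covers this change, since the one step known exchanges two other groups, so the direction is uncertain. Going by the values given here, a modest move back toward the middle of the two known numbers is expected, a 2.0-fold lower number from compound 2 to compound 3 (0.30 log units; within the scatter). Compound 3 is therefore estimated at 250 mg/kg, with a range from 80 mg/kg to 800 mg/kg.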

Compound 3, dose for half-maximal effect: 500 mg/kg
Compound 3: the middle estimate sits 2.0-fold (0.30 log units) below what was measured; the range from low to high includes it.
By their numbers in this assay, from the lowest: compound 1; then compounds 2 and 3 (each within the scatter of the next).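

In this assay the swap to 4-fluorophenyl in place of 3-chlorophenyl gives no change at the digits printed from compound 2 to compound 3 (within the scatter) and so does not separate these two phenyl groups at this position on the shared core. The halogen and its place on the phenyl ring change together here, so the contribution of each alone cannot be read. Nothing available explains this result. Still open, as far as these compounds go, is how this position would respond to an amine or a carboxylic acid on the phenyl ring.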